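Swapping methylthiophenyl for hydroxyphenyl on the shared core

The source may hold more compounds than are shown below. What is called first, only, known or untested is meant among the compounds shown, and "the series" means these compounds.

Among the compounds with values here, compound 1 `Cc1ccsc1-c1ncnc2c1ncn2C1O[C@H](CO)[C@@H](O)[C@H]1O` is one of three compounds measured in a functional assay on HL-60 cells (Homo sapiens) for inhibition (on this read-out lower numbers stand for stronger inhibition and higher numbers for weaker inhibition), where compound 1 gives 4500 nM. Among the three numbers it stands second highest. Its nearest neighbour is compound 3 `OC[C@H]1OC(n2cnc3c(-c4ccsc4)ncnc32)[C@H](O)[C@@H]1O`, which in this assay gives 3800 nM; the step of a 1.2-fold lower number from compound 1 to compound 3 (0.07 log units; within the scatter) lies within the scatter. Furthest from it is compound 2 `Cc1csc(-c2ncnc3c2ncn3C2O[C@H](CO)[C@@H](O)[C@H]2O)c1`, which in this assay gives 5600 nM; the step of a 1.2-fold higher number from compound 1 to compound 2 (0.09 log units; within the scatter) is also within the scatter, as is the step of a 1.5-fold lower number from compound 2 to compound 3 (0.17 log units; within the scatter).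

Compound 4 `OC[C@H]1OC(n2cnc3c(-c4ccc(O)cc4)ncnc32)[C@H](O)[C@@H]1O` has not yet been measured. It differs from compound 1 by 4-hydroxyphenyl in place of 3-methylthiophen-2-yl on an aromatic carbon. None of the three measured steps covers a change of this kind: each of them exchanges the 3-methylthiophen-2-yl, 4-methylthiophen-2-yl or thiophen-3-yl group for another of the three, and all of them stay within the scatter. Within the data shown here, the entry of a 4-hydroxyphenyl group has no counterpart among the measured pairs, so the data give no direction for it. The expected step is therefore no change at the digits printed from compound 1 to compound 4 (within the scatter), carried with a wide range. Compound 4 is estimated to give 4500 nM in this assay, with a range from 1500 nM to 14000 nM.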

Compound 4, half-maximal inhibitory concentration: 7600 nM
Compound 4: middle estimate off by 1.7-fold (0.23 log units), on the low side, within the range that was stated.
By their numbers in this assay, from the lowest: compounds 3, 1, 2 and 4 (each within the scatter of the next).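

In this assay, within the data shown here, the 4-hydroxyphenyl group is the first entry at this position that leaves the five-membered sulfur rings for a six-membered aromatic ring of carbon only, and it also brings a hydrogen-bond donor that the three thiophene groups lack. The steps of a 1.7-fold higher number from compound 1 to compound 4 (0.23 log units; within the scatter) and a 2.0-fold higher number from compound 3 to compound 4 (0.30 log units; within the scatter) and a 1.4-fold higher number from compound 2 to compound 4 (0.13 log units; within the scatter) all lie within the scatter, so this larger exchange on the aromatic carbon next to the ring nitrogen separates compound 4 from none of the three earlier compounds, and all four compounds remain inseparable at this position on this read-out. Nothing at hand explains why such different groups leave the numbers this close.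

The single exchange alters the ring and adds the hydroxyl together, so the compounds shown cannot assign any part of the steps to either, and an unsubstituted phenyl would be needed to divide them. Going by these compounds, it also remains open whether any group here can move the number beyond the scatter, for instance a phenyl carrying an amine or a carboxylic acid in place of the hydroxyl.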